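This account rests on a few compounds, and the source may have more. Where it says the series, first, only, none or still open, it means among the compounds named here.

Measured in an ADME assay on Vero cells (Chlorocebus sabaeus) for cytotoxicity, read by MTT assay, with a stated time of 72 h; on this read-out higher numbers stand for weaker inhibition and lower numbers for stronger inhibition:
Compound 1 `CN(C)c1ccc(C2CC(c3cc4ccccc4o3)=NN2C(=O)c2ccncc2)cc1` gives > 210000 nM, a limit of the assay.
Compound 2 `O=C(O)c1ccccc1C1CC(c2cc3ccccc3o2)=NN1C(=O)c1ccncc1` gives > 170000 nM, a limit of the assay.
Compound 3 `O=C(c1ccncc1)N1N=C(c2cc3ccccc3o2)CC1c1cccc([N+](=O)[O-])c1` gives > 240000 nM, a limit of the assay.

Compound 3 thus stands only at a limit, as do the other two values; this leaves a step that the two limits leave unreadable from compound 1 to compound 3 and a step that the two limits leave unreadable from compound 2 to compound 3 unreadable, as it does a step that the two limits leave unreadable from compound 1 to compound 2. Compound 4 `COc1ccc(C2CC(c3cc4ccccc4o3)=NN2C(=O)c2ccncc2)c(O)c1` differs from compound 3 by 2-hydroxy-4-methoxyphenyl in place of 3-nitrophenyl on a saturated ring carbon. Among the compounds with values here, the three steps above bear on this change, all of unreadable size; the limits (the limit of > 170000 nM in this assay, at which 1 of the 3 values shown sits), the limit of > 210000 nM in this assay, at which 1 of the 3 values shown sits, and the limit of > 240000 nM in this assay, at which 1 of the 3 values shown sits, show no compound within the tested range. No step beyond the scatter is therefore expected in this assay, and compound 4 will most likely also reach only a limit. Compound 4 is estimated at 200000 nM, with a range from 100000 nM to 400000 nM. The expected step, an at least 1.2-fold lower number from compound 3 to compound 4 (0.07 log units; that floor lies within the scatter), is within the scatter.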

Compound 4, half-maximal inhibitory concentration: > 190000 nM
Compound 4 gave a limit, no number; the forecaster's own chance of this, stated with the estimate: 85%; the middle value lies beyond the limit too.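

In this assay compound 4 gives > 190000 nM, a limit of the assay and not a number. Its steps to compound 1, compound 2 and compound 3 cannot be read. The compounds shown leave open how the groups on the saturated ring carbon rank in this assay.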